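Dimethylamino in place of amino on a dioxane chain

The source may hold more compounds than are shown below. What is called first, only, known or untested is meant among the compounds shown, and "the series" means these compounds.

In an assay for displacement of a labelled ligand from Sigma non-opioid intracellular receptor 1 (Cavia porcellus), read by scintillation counting (on this read-out lower numbers stand for stronger inhibition and higher numbers for weaker inhibition), compound 3 `NCCC[C@@H]1CCO[C@H](c2ccccc2)O1` gives 167 nM. Compound 2 `c1ccc(CNCC[C@@H]2CCOC(c3ccccc3)(c3ccccc3)O2)cc1` gives 320 nM, and the two numbers lie within the scatter of each other, so nothing separates them. Compound 1 `CNCC[C@@H]1CCO[C@H](c2ccccc2)O1` gives 449 nM, and the step of a 2.7-fold lower number from compound 1 to compound 3 (0.43 log units; beyond the scatter) is beyond the scatter. Compound 4 `CN(C)CCC[C@@H]1CCO[C@H](c2ccccc2)O1` differs from compound 3 in one place: dimethylamino in place of amino on a saturated chain carbon, three bonds along the chain from a saturated ring carbon. Among the compounds with values here, the one measured step that bears on this is the step from compound 1 to compound 3, where taking a methyl off the chain nitrogen gave a lower number; compound 4 goes the other way and puts two methyls on that nitrogen. Compound 2, with a benzyl on its nitrogen, offers no single-place comparison and its value sits close to compound 3. On that basis compound 4 is expected to give a modestly higher number in this assay, about a 4.2-fold higher number from compound 3 to compound 4 (0.62 log units; beyond the scatter), though a result within the scatter would not surprise. The estimate for compound 4 is 700 nM, with a range from 250 nM to 2000 nM.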

Compound 4, inhibition constant: 1220 nM
Estimate against measurement, compound 4: 1.7-fold (0.24 log units) below, within the range that was stated.
By their numbers in this assay, from the lowest: compounds 3, 2 and 1 (each within the scatter of the next, the first and the last beyond it); then compound 4.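

In this assay, putting dimethylamino in place of amino at this position, on a saturated chain carbon three bonds along the chain from a saturated ring carbon, gives the largest step shown so far: a 7.3-fold higher number from compound 3 to compound 4 (0.86 log units; beyond the scatter). Compound 4 also separates from the shorter-chain compound, with a 2.7-fold higher number from compound 1 to compound 4 (0.43 log units; beyond the scatter). The earlier compounds shown here showed only a modest step on the chain, and these two steps show that the amine at this position can move the number further. Nothing measured here explains the change.

The compounds shown leave open how a 3-(methylamino)propyl chain would read, and so whether one methyl on the nitrogen already accounts for the rise or whether both are needed. Also open, from the compounds shown here alone, is how a piperidine or a benzylamino group in place of amino at this position, or a longer chain, would compare.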